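Methyl in Place of Methylsulfanyl on the Core

The source may report more compounds than this note shows. Statements on the series, on what has been measured and on what is new or still open speak of the compounds shown alone.

Measured compounds:
compound 1 `COc1nc(C)cc(SC)c1NC(=O)N(Cc1ccc(Oc2ccc(F)cc2)cc1)C1CCCCCC1`: 29 nM
compound 2 `CSc1nc(C)cc(Cl)c1NC(=O)N(Cc1ccc(Oc2ccc(F)cc2)cc1)C1CCCCCC1`: 12 nM
compound 3 `CSc1cc(C)nc(C)c1NC(=O)N(Cc1ccc(Oc2ccc(F)cc2)cc1)C1CCCCCC1`: 90 nM

In an assay for inhibition of acyl-CoA:cholesterol acyltransferase (Oryctolagus cuniculus), using microsomes (on this read-out lower numbers stand for stronger inhibition and higher numbers for weaker inhibition), compound 3 gives the highest number of the three, with a 3.1-fold higher number from compound 1 to compound 3 (0.49 log units; beyond the scatter) and a 7.5-fold higher number from compound 2 to compound 3 (0.88 log units; beyond the scatter) both beyond the scatter. Compound 4 `Cc1cc(C)c(NC(=O)N(Cc2ccc(Oc3ccc(F)cc3)cc2)C2CCCCCC2)c(C)n1` differs from compound 3 by methyl in place of methylsulfanyl on an aromatic carbon. Among the compounds with values here, no measured step removes a methylsulfanyl group, so none bears on it directly. The closest is a 3.1-fold higher number from compound 1 to compound 3 (0.49 log units; beyond the scatter), where methyl also entered the core and inhibition weakened; the step of a 2.4-fold lower number from compound 1 to compound 2 (0.38 log units; beyond the scatter) changed several groups at once and bears little. A modest weakening is therefore expected, a 2.0-fold higher number from compound 3 to compound 4 (0.30 log units; within the scatter). Compound 4 is estimated at 180 nM, with a range from 70 nM to 500 nM.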

Compound 4, half-maximal inhibitory concentration: 62 nM
Beside the measured number, compound 4's estimate is 2.9-fold (0.46 log units) above it; measured number below the stated range.
By their numbers in this assay, from the lowest: compound 2; then compound 1; then compounds 4 and 3 (each within the scatter of the next).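

In this assay, within the data shown here, a 1.5-fold lower number from compound 3 to compound 4 (0.16 log units; within the scatter) lies within the scatter, so at this place, opposite the ring nitrogen, the methylsulfanyl group can give way to methyl with no difference the assay can resolve, something no earlier compound could show. The steps of a 5.2-fold higher number from compound 2 to compound 4 (0.71 log units; beyond the scatter) and a 2.1-fold higher number from compound 1 to compound 4 (0.33 log units; beyond the scatter) alter more than one group on the core and so do not isolate this position. Nothing measured here offers an explanation for this result. The compounds shown leave open whether an amine or an ethyl group at this place would read the same.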